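Adding a third methoxy group to a dimethoxyphenyl tricyclic

The source may report more compounds than this note shows. Statements on the series, on what has been measured and on what is new or still open speak of the compounds shown alone.

Measured compounds in an ADME assay on MDCK cells (Canis lupus familiaris) for cytotoxicity, read by MTT assay, with a stated time of 48 h; on this read-out lower numbers stand for higher toxicity in this test and higher numbers for lower toxicity in this test:
- compound 1, `C[C@@H]1CC[C@@H]2[C@@H](C1)O[C@@H](c1ccccc1)CC2(C)O`: 580000 nM
- compound 2, `COc1ccc([C@H]2CC(C)(O)[C@@H]3CC[C@@H](C)C[C@H]3O2)c(OC)c1`: > 937000 nM
- compound 3, `COc1ccc(OC)c([C@H]2CC(C)(O)[C@@H]3CC[C@@H](C)C[C@H]3O2)c1`: 512000 nM

Three compounds share the same bicyclic core and differ only in the aromatic ring attached to it. In this assay compound 1 gives 580000 nM. For compound 2 the assay reports only a limit, > 937000 nM, and no number. Compound 3 gives 512000 nM in this assay; of the two numbers shown it is the lower one, but its nearest neighbour, compound 1, sits within the usual scatter of it, so the two cannot be told apart.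

Compound 4, `COc1cc(OC)c([C@H]2CC(C)(O)[C@@H]3CC[C@@H](C)C[C@H]3O2)cc1OC`, differs from compound 3 by one change: methoxy in place of hydrogen on an aromatic carbon. For the measured compounds named here, no measured pair shows this kind of change, so there is no step to lean on. The three aromatic variants shown are all close to each other or at the limit, and the expected step in this assay from compound 3 to compound 4 is none beyond the scatter, a 1.1-fold higher number from compound 3 to compound 4 (0.03 log units; within the scatter). Compound 4 is therefore estimated at 550000 nM, with a range from 250000 nM to 1100000 nM.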

Compound 4, half-maximal cytotoxic concentration: > 857000 nM
Compound 4: no number, only a limit; the forecaster's own chance of this, stated with the estimate: 30%; middle value at least 1.5-fold (0.19 log units) from the limit.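

For the compounds shown here, with methoxy in place of hydrogen on an aromatic carbon, ortho to a methoxy group and meta to a methoxy group, this assay gives the first step of this kind: an at least 1.6-fold higher number from compound 3 to compound 4 (0.22 log units; that floor lies within the scatter). The change therefore does not move the read-out toward a lower number here, although the floor of the step alone does not establish a change beyond the scatter. Compound 4 gives no number, only a limit, as compound 2 does, and the step between these two cannot be read: the limit of > 857000 nM in this assay, at which 1 of the 4 values shown sits.

Still open, on these data alone, is how far the true value of compound 4 lies from its limit. The compounds shown also leave open whether an amine or a carboxylic acid on this aromatic carbon would give a lower number than methoxy.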